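The source may hold more compounds than are shown below. What is called first, only, known or untested is meant among the compounds shown, and "the series" means these compounds.

The measured compounds:

Compound 1, `COc1cc2cc(Oc3ccc(NC(=O)Nc4cccc(C(F)(F)F)c4)cc3)c(C)nc2cc1OC`, gives 1480 nM in a functional assay on EKVX cells (Homo sapiens) for inhibition, read by sulforhodamine B assay, with a stated time of 48 h; a lower number here means a stronger inhibitor of growth, a higher number a weaker inhibitor of growth.
Compound 2, `COc1cc2cc(Oc3ccc(NC(=O)Nc4ccc(Cl)c(C(F)(F)F)c4)cc3)c(C)nc2cc1OC`, gives 1010 nM in this assay.

Of these two numbers, compound 2 carries the smaller one, yet the step of a 1.5-fold lower number from compound 1 to compound 2 (0.17 log units; within the scatter) is within the scatter, so the two compounds cannot be told apart by this assay.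

Compound 3, `COc1cc2cc(Oc3ccc(NC(=O)Nc4ccc(Cl)c(Cl)c4)cc3)c(C)nc2cc1OC`, differs from compound 2 by chloro in place of trifluoromethyl on an aromatic carbon. For the measured compounds named here, no measured step swaps a trifluoromethyl for a chloro. Going by the values given here, the only measured step, a 1.5-fold lower number from compound 1 to compound 2 (0.17 log units; within the scatter), is a change on the same ring and stayed within the scatter, which gives no direction for the present change. With nothing pointing either way, the number for compound 3 is expected to stay close to that of compound 2, a step of a 1.2-fold higher number from compound 2 to compound 3 (0.07 log units; within the scatter) that is estimated to lie within the scatter. The estimate for compound 3 is 1200 nM, expected between 500 nM and 3000 nM.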

Compound 3, concentration for 50% growth inhibition: 2360 nM
Estimate against measurement, compound 3: 2.0-fold (0.29 log units) below; measured number inside the range.
By their numbers in this assay, from the lowest: compounds 2, 1 and 3 (each within the scatter of the next, the first and the last beyond it).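

For the compounds shown here, this is the first step to go beyond the scatter. In this assay, putting chloro in place of trifluoromethyl on the aromatic carbon ortho to a chloro group gives a 2.3-fold higher number from compound 2 to compound 3 (0.37 log units; beyond the scatter) and so shows, modestly, that the number responds to the group held at this position. The wider change of 3,4-dichlorophenyl in place of 3-(trifluoromethyl)phenyl gives a 1.6-fold higher number from compound 1 to compound 3 (0.20 log units; within the scatter) and stays within the scatter, so the only clear separation is the one between the trifluoromethyl and chloro pair that both carry the second chloro group, and no measurement here explains it.

From the compounds shown here alone, whether a bromo, a methyl or a nitrile on that carbon would give a number nearer that of trifluoromethyl or that of chloro stays open. Also open, going by these compounds, is whether the gap between trifluoromethyl and chloro would hold on a ring without the other chloro group.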